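This account rests on a few compounds, and the source may have more. Where it says the series, first, only, none or still open, it means among the compounds named here.

Compound 2, `Oc1ccc(-c2cc(-c3cccc(O)c3)nc(-c3cccc(O)c3)c2)cc1`, carries two 3-hydroxyphenyl groups on the shared core. In an ADME assay on HEK293 cells (Homo sapiens) for cytotoxicity, read by CCK-8 assay, with a stated time of 4 days (a lower number here means a stronger inhibitor, a higher number a weaker inhibitor), compound 2 gives 730 nM. Compound 1, `Oc1ccc(-c2cc(-c3ccc(O)cc3)nc(-c3ccc(O)cc3)c2)cc1`, carries two 4-hydroxyphenyl groups instead, and in this assay compound 1 gives 790 nM. These two numbers lie within the usual scatter of each other, so on the numbers shown compound 2 does not stand apart from compound 1.

Compound 3, `Oc1ccc(-c2cc(-c3ccc(O)cc3)nc(-c3cccc(O)c3)c2)cc1`, has not yet been measured. It differs from compound 2 in a single place: 4-hydroxyphenyl in place of 3-hydroxyphenyl on an aromatic carbon. Compound 3 thus holds one group of each kind and sits, in its structure, between compound 1 and compound 2. Going by the values given here, those two measured values differ by less than the scatter, and no other step is known. No change beyond the scatter is therefore expected for a 1.0-fold higher number from compound 2 to compound 3 (0.02 log units; within the scatter). Compound 3 is expected to give about 760 nM in this assay, with a likely range from 400 nM to 1450 nM.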

Compound 3, half-maximal inhibitory concentration: 840 nM
For compound 3 the middle estimate is 1.1-fold (0.04 log units) below the measured one, within the range that was stated.
By their numbers in this assay, from the lowest: compounds 2, 1 and 3 (each within the scatter of the next).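

Exchanging 3-hydroxyphenyl for 4-hydroxyphenyl at this place, on the aromatic carbon next to the ring nitrogen, gives a 1.2-fold higher number from compound 2 to compound 3 (0.06 log units; within the scatter) in this assay, while the opposite exchange gives a 1.1-fold higher number from compound 1 to compound 3 (0.03 log units; within the scatter). The earlier pair differed in two places at once, whereas these steps each isolate a single exchange, and neither separates the compounds: compound 3, with one group of each kind, does not stand apart from compound 1 or compound 2. Nothing shown explains why the exchange leaves the number within the scatter.

On these data alone, all three compounds carry only these two hydroxyphenyl groups, so it remains open whether a methoxyphenyl group, an aminophenyl group or a carboxylic acid at this place would give a clearly different number. As far as these compounds go, it also remains open whether the same holds in any other cell type.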